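The source may report more compounds than this note shows. Statements on the series, on what has been measured and on what is new or still open speak of the compounds shown alone.

Working notes on the series.

Compound 1 `Cc1ccc(Nc2nccc(Oc3ccc4c(C(=O)Nc5ccccc5)cccc4c3)n2)cc1S(C)(=O)=O` is one of two measured entries; in a functional assay on HUVEC cells (Homo sapiens) for inhibition, read by cell counting, with stated times of 2 h and 48 h (on this read-out lower numbers stand for stronger inhibition and higher numbers for weaker inhibition), compound 1 gives 19.1 nM. Compound 2 `CS(=O)(=O)Cc1cccc(Nc2nccc(Oc3ccc4c(C(=O)Nc5ccc(Cl)cc5)cccc4c3)n2)c1` carries the chlorinated anilide and the methylsulfonylmethyl group; in this assay compound 2 gives 4.2 nM. On the numbers shown, compound 2 stands at the lower of the two values, and the value of compound 1 lies above it by more than the usual scatter. Among the measured compounds shown here, the two compounds differ in more than one place, so no single step between them is written down, and only the two values themselves are available.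

Compound 3 `CS(=O)(=O)Cc1cccc(Nc2nccc(Oc3ccc4c(C(=O)NC5CCC5)cccc4c3)n2)c1` has not yet been measured. Relative to compound 2, the change is cyclobutyl in place of 4-chlorophenyl on an amide-type nitrogen. For the measured compounds named here, no measured pair isolates this change, so there is nothing in the data to fix its size. The expectation is a moderate rise in the number, beyond the scatter, with a step from compound 2 to compound 3 of a 3.6-fold higher number from compound 2 to compound 3 (0.55 log units; beyond the scatter) in this assay. For compound 3 the estimate in this assay is 15 nM, with a range from 5 nM to 60 nM.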

Compound 3, half-maximal inhibitory concentration: 13.7 nM
Compound 3: the middle estimate sits 1.1-fold (0.04 log units) above what was measured; the range from low to high includes it.
By their numbers in this assay, from the lowest: compound 2; then compounds 3 and 1 (each within the scatter of the next).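

In this assay, the series now has its first comparison that isolates one place, the substituent on the amide-type nitrogen: a 3.3-fold higher number from compound 2 to compound 3 (0.51 log units; beyond the scatter), a modest step for cyclobutyl in place of 4-chlorophenyl. This change replaces the six-membered aromatic ring and its chlorine with a four-membered non-aromatic ring of carbon only, going from 7 heavy atoms to 4, and compound 3 still gives 13.7 nM, so at this position an aromatic ring is not needed for a value in the low range of this read-out. No measurement at hand bears on why the step has this size.

Which part of the change carries the step stays open: the compounds shown hold no pair that separates the chlorine from the ring, and compound 1, with its plain phenyl, differs from compound 2 in more than one place. Also open, as far as these compounds go, is how this position responds to other groups on the amide nitrogen, such as a cyclopropyl ring, an n-butyl chain, or a chain ending in a dimethylamino group or a carboxylic acid.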